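The source may report more compounds than this note shows. Statements on the series, on what has been measured and on what is new or still open speak of the compounds shown alone.

Measured compounds and their values in an assay on BaF3 cells for inhibition of proto-oncogene tyrosine-protein kinase receptor Ret variant V804M (Homo sapiens), read by MTT assay, with a stated time of 48 h; a higher number here means a weaker inhibitor of growth, a lower number a stronger inhibitor of growth:
compound 1 `Nc1ncnc2c1c(-c1cc(C3CC3)on1)nn2C1CCCCC1`: 2000 nM
compound 2 `CC(C)(O)Cn1nc(-c2cc(C3CC3)on2)c2c(N)ncnc21`: 6750 nM
compound 3 `CCCCCCCn1nc(-c2cc(C3CC3)on2)c2c(N)ncnc21`: > 10000 nM

Compound 3 stands at the limit of > 10000 nM in this assay, at which 1 of the 3 values shown sits, so its value is a limit of this assay and not a number. The three compounds share one core and differ only in the group on the aromatic nitrogen. Compound 1, with cyclohexyl there, gives the lowest value, and a 3.4-fold higher number from compound 1 to compound 2 (0.53 log units; beyond the scatter) as well as an at least 5.0-fold higher number from compound 1 to compound 3 (0.69 log units; beyond the scatter), while an at least 1.4-fold higher number from compound 2 to compound 3 (0.17 log units; that floor lies within the scatter).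

Compound 4 `Cn1nc(-c2cc(C3CC3)on2)c2c(N)ncnc21` carries the change (hydrogen in place of hexyl on a saturated chain carbon bound to an aromatic nitrogen). For the measured compounds named here, this shortens the chain to the smallest possible group on that nitrogen, a direction in which none of the measured steps point; the steps to compound 3 show only that heptyl is the weakest of the three groups, so the return to a small group is expected to bring the number down, with an at least 2.0-fold lower number from compound 3 to compound 4 (0.30 log units; that floor lies within the scatter). Compound 4 is therefore expected to reach about 5000 nM in this assay, within 1500 nM to 15000 nM.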

Compound 4, concentration for 50% growth inhibition: 5560 nM
Compound 4: middle estimate off by 1.1-fold (0.05 log units), on the low side; the range from low to high includes it.
By their numbers in this assay, from the lowest: compound 1; then compounds 4 and 2 (each within the scatter of the next). At a limit, above all of these: compound 3.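

In this assay, cutting the group on the aromatic nitrogen down to methyl does not bring back what cyclohexyl gives: the data show a 2.8-fold higher number from compound 1 to compound 4 (0.44 log units; beyond the scatter) and so a small group alone is not enough. Methyl and 2-hydroxy-2-methylpropyl cannot be told apart, with a 1.2-fold lower number from compound 2 to compound 4 (0.08 log units; within the scatter) in this pair, so among these compounds only the cyclohexyl of compound 1 stands clearly lower than the rest. Against heptyl the data give only an at least 1.7-fold lower number from compound 3 to compound 4 (0.25 log units; that floor lies within the scatter) and the true size of that step stays unknown, since compound 3 carries a limit and not a number: the limit of > 10000 nM in this assay, at which 1 of the 4 values shown sits.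

As far as these compounds go, whether another ring such as cyclopentyl or cyclopropyl, or a branched group such as isopropyl, would keep the lower number remains open. So does the effect of an amine or a carboxylic acid on the chain.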